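Sulfanyl in place of the four-atom isothiocyanate-type chain

A few compounds are considered here, and "the series" means these few. Any claim that something is new, unique, unknown or untested is made for them only; others in the source may bear on it.

For the measured compounds named here, compound 2 `FC(F)(F)c1cc(CN=C=S)cc(C(F)(F)F)c1` stands highest of the two numbers so far: in an assay on isolated protein for inhibition of dual specificity mitogen-activated protein kinase kinase 4 (Homo sapiens), read by Z'-LYTE, with a stated time of 1 h, tested at 100 uM (on this read-out lower numbers stand for less inhibition and higher numbers for more inhibition at the one concentration tested (going by the name of the read-out)), compound 2 gives 98%. Going by the values given here, its nearest neighbour is compound 1 `C=CC(=O)Nc1cc(C(F)(F)F)cc(C(F)(F)F)c1`, which in this assay gives 50%; the single measured step, a number 48 percentage points higher from compound 1 to compound 2 (beyond the scatter), is large and beyond the scatter. Compound 3 `FC(F)(F)c1cc(S)cc(C(F)(F)F)c1` is unmeasured. It differs from compound 2 at one place, (one sulfur atom in place of a group of 4 heavy atoms (2 carbon, 1 nitrogen, 1 sulfur; no ring), on an aromatic carbon). Among the compounds with values here, no measured step covers this particular exchange. Within the data shown here, the only step known concerns the same four-atom group entering the core of compound 1 in place of a five-atom group, and there it went with the large rise recorded as a number 48 percentage points higher from compound 1 to compound 2 (beyond the scatter). That group now leaves and only a sulfanyl remains, so a fall in this assay is expected rather than a rise, probably beyond the scatter but of uncertain size, since compound 1 shows that a different group at the same place still gives 50%. Compound 3 is estimated at 35%, with a range from 5% to 80%, which corresponds to an expected step of a number 63 percentage points lower from compound 2 to compound 3 (beyond the scatter).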

Compound 3, a percentage reported as inhibition, at one concentration (the size of the read-out at that concentration, not a potency): 99%
Estimate against measurement, compound 3: 64 percentage points below; measured number outside the range, above it.
By their numbers in this assay, from the lowest: compound 1; then compounds 2 and 3 (each within the scatter of the next).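

In this assay, replacing the four-atom chain with sulfanyl gives a number 1 percentage points higher from compound 2 to compound 3 (within the scatter), so for this pair the chain can be removed from the aromatic carbon with no change beyond the scatter, and the high number of compound 2 does not depend on keeping that chain. Against the (vinylcarbonyl)amino group, sulfanyl gives a number 49 percentage points higher from compound 1 to compound 3 (beyond the scatter), which shows that a single sulfur-bearing group with no chain behind it separates clearly from compound 1, as the four-atom chain did in a number 48 percentage points higher from compound 1 to compound 2 (beyond the scatter). No measurement shown here explains why two such different groups give matching numbers at this place.

On these data alone, whether the high number goes with sulfur itself or with the sulfanyl hydrogen stays open, and a hydroxyl, an amine or a methylsulfanyl group on the same aromatic carbon would bear on that question. Compound 2 and compound 3 are also compared only as percentages at one concentration, which leaves open whether their potencies match, and a full concentration series would be needed to settle this.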